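The compounds below may be only part of what the source reports. "The series", "measured", "known", "first", "only" and "open" are said of these compounds alone.

Compound 1 `COc1cc(-c2nn(-c3cccc(NC(=O)c4cccc(C(F)(F)F)c4)c3)cc2-c2ccncc2)ccc1Cl` gives > 50000 nM in a functional assay on NCI-H322M cells (Homo sapiens) for inhibition, read by sulforhodamine B assay, with a stated time of 48 h (on this read-out lower numbers stand for stronger inhibition of growth and higher numbers for weaker inhibition of growth), which is a limit of the assay rather than a number.
Compound 2 `COc1cc(-c2nn(-c3cccc(NC(=O)Nc4cccc(C(F)(F)F)c4)c3)cc2-c2ccncc2)ccc1Cl` gives 4730 nM in this assay.

Among these two, compound 2 holds the only numerical value shown; the other entry is a limit. Compound 3 `COc1cc(-c2nn(-c3cccc(NC(=O)c4ccc(Cl)c(C(F)(F)F)c4)c3)cc2-c2ccncc2)ccc1Cl` has not been measured. It differs from compound 2 by 4-chloro-3-(trifluoromethyl)phenyl in place of (3-(trifluoromethyl)phenyl)amino on a carbonyl carbon. Among the measured compounds shown here, the one measured step bears directly on this: an at least 10-fold lower number from compound 1 to compound 2 (1.02 log units; beyond the scatter), moving from an amide to a urea. For the measured compounds named here, compound 3 reverses that move, returning to an amide while adding a chlorine to the ring, and the only comparison for an amide here is compound 1, which sits at the limit of > 50000 nM in this assay, at which 1 of the 2 values shown sits. The expected step is therefore a return toward weaker inhibition, an 8.5-fold higher number from compound 2 to compound 3 (0.93 log units; beyond the scatter), with a real chance that only a limit is reported. For compound 3 the estimate in this assay is 40000 nM, between 10000 nM and 150000 nM.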

Compound 3, concentration for total growth inhibition: > 32500 nM
Compound 3: only a limit was reported; the forecaster's own chance of this, stated with the estimate: 60%; the middle value does not contradict the limit.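

Swapping (3-(trifluoromethyl)phenyl)amino for 4-chloro-3-(trifluoromethyl)phenyl on the carbonyl carbon gives an at least 6.8-fold higher number from compound 2 to compound 3 (0.83 log units; beyond the scatter). The earlier amide and urea comparison now has a second amide behind it, and adding a chloro to the aromatic ring does not bring a measured number back in this assay, since compound 3 gives only a limit: the limit of > 32500 nM in this assay, at which 1 of the 3 values shown sits. Compound 1 also gives only a limit, so the step from compound 1 to compound 3, chloro in place of hydrogen, cannot be read.

As far as these compounds go, what the same chloro would do on the urea of compound 2 stays open. Also open, from the compounds shown here alone, is whether a benzyloxy group on the carbonyl carbon, which would make a carbamate, would behave more like the urea or like the amides.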